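Trimming a Methyl on a Liver Microsome Stable Core

This account rests on a few compounds, and the source may have more. Where it says the series, first, only, none or still open, it means among the compounds named here.

Measured compounds:
compound 1 `COC(=O)Nc1cc(-c2cnc(OC[C@@](C)(N)CC(C)C)cc2C)ccn1`: 87%
compound 2 `COC(=O)Nc1cc(-c2ccc(OC[C@@](C)(N)CC(C)C)cn2)ccn1`: 100%

In an ADME assay on microsomes from liver (Rattus norvegicus) for metabolic stability, read by LC-MS, using NADPH, with a stated time of 10 min, tested at 0.5 uM (on this read-out higher numbers stand for a more stable compound and lower numbers for a less stable compound), compound 1 gives 87% and stands lowest of the two numbers. Compound 2 gives 100% in this assay, a number beyond the scatter higher, but the two structures differ in more than one place, so their pair tells nothing about any single change.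

Compound 3 `COC(=O)Nc1cc(-c2ccc(OC[C@@](C)(N)CC(C)C)nc2)ccn1` is the compound awaiting measurement. It differs from compound 1 in one place: hydrogen in place of methyl on an aromatic carbon.

Within the data shown here, with no one-place step among the measured compounds, the expectation rests on compound 1 alone. Compound 1 already sits high, so the step of a number 3 percentage points higher from compound 1 to compound 3 (within the scatter) is expected to be small, upward or not beyond the scatter. Compound 3 is therefore expected to give about 90% in this assay. Its range is estimated from 76% to 100%.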

Compound 3, percent of the compound remaining: 96%
For compound 3 the middle estimate is 6 percentage points below the measured one; the measured number falls inside the stated range.
By their numbers in this assay, from the lowest: compounds 1, 3 and 2 (each within the scatter of the next, the first and the last beyond it).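

Among these compounds, with hydrogen in place of methyl on an aromatic carbon, opposite the ring nitrogen and ortho to a large group, this assay shows a number 9 percentage points higher from compound 1 to compound 3 (within the scatter), the first reading of a single change on this core. Compound 1 and compound 3 therefore cannot be told apart on this read-out, and the methyl is not required for the number to stay high on this core. Nothing measured here bears on why the exchange leaves the number within the scatter.

The compounds shown leave open what an ethyl group, a methoxy group or a chlorine atom on this same carbon would give. They also leave open whether the same exchange would give a step of this size on a core with a much lower number.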